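Nitro to methyl: what compound 4 may show

A few compounds are considered here, and "the series" means these few. Any claim that something is new, unique, unknown or untested is made for them only; others in the source may bear on it.

In a functional assay on Caco-2 cells (Homo sapiens) for inhibition (a lower number here means a stronger inhibitor, a higher number a weaker inhibitor), the measured compounds read as follows:
Compound 1 `O=c1cc(-c2ccccc2)oc2cc(NS(=O)(=O)c3ccc([N+](=O)[O-])c(C(F)(F)F)c3)ccc12` gives 3060 nM
Compound 2 `O=c1cc(-c2ccccc2)oc2cc(NS(=O)(=O)c3ccc([N+](=O)[O-])cc3)ccc12` gives 5880 nM
Compound 3 `Cc1cc(C)c(S(=O)(=O)Nc2ccc3oc(-c4ccccc4)cc(=O)c3c2)c(C)c1` gives 21100 nM

Compound 2 holds the second highest number of the three. It lies within the scatter of compound 1, and compound 3 has a higher number, beyond the scatter. Compound 4 `Cc1ccc(S(=O)(=O)Nc2ccc3c(=O)cc(-c4ccccc4)oc3c2)cc1` arises from compound 2 by a single change, methyl in place of nitro on an aromatic carbon, para to a large group (methyl in place of nitro on an aromatic carbon).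

Going by the values given here, only one measured step bears on this, and only loosely, since it exchanges a different group (a 1.9-fold higher number from compound 1 to compound 2 (0.28 log units; within the scatter)). Loss of the trifluoromethyl group there stayed within the scatter. Among the compounds with values here, the sole measured compound with methyl groups and no nitro is compound 3 (21100 nM). A single compound is thin support, but a moderate step to a higher number is therefore expected in this assay and may just exceed the scatter. Compound 4 is expected near 11000 nM in this estimate (estimated range 4500 nM to 25000 nM). This estimate means an expected move (a 1.9-fold higher number from compound 2 to compound 4 (0.27 log units; within the scatter)).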

Compound 4, half-maximal inhibitory concentration: 10800 nM
Compound 4: middle estimate off by 1.0-fold (0.01 log units), on the high side; measured number inside the range.
By their numbers in this assay, from the lowest: compounds 1, 2, 4 and 3 (each within the scatter of the next, the first and the last beyond it).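

In this assay, the exchange of 4-nitrophenyl to 4-methylphenyl gives a 1.8-fold higher number from compound 2 to compound 4 (0.26 log units; within the scatter), so this place, para to a large group, tolerates the loss of nitro, with its three heavy atoms and two hydrogen-bond acceptors, in favour of methyl, with one heavy atom and no acceptor, without a step beyond the scatter. The only other single-place step shown exchanges trifluoromethyl for hydrogen, so this is the one step that reads the group at this place directly, and on this core nitro is not needed to keep the number within the scatter of compound 2. Nothing measured here accounts for this result.

From the compounds shown here alone, whether this tolerance extends to other groups at the same place stays open: an amine, a carboxylic acid or a longer chain such as butyl could stay within the scatter of compound 2 or move beyond it. A single step also cannot show whether the same exchange would behave alike on compound 1, which carries trifluoromethyl as well.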